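The source may hold more compounds than are shown below. What is called first, only, known or untested is meant among the compounds shown, and "the series" means these compounds.

Of the compounds shown here, three with a shared core have been measured in an ADME assay on Vero cells (Chlorocebus sabaeus) for inhibition; on this read-out higher numbers stand for lower toxicity in this test and lower numbers for higher toxicity in this test. Compound 1 `O=C1/C(=C/c2ccc(Cl)cc2)CCC/C1=C\c1ccc(Cl)cc1` gives 32100 nM and compound 2 `O=C1/C(=C/c2ccccc2Cl)CCC/C1=C\c1ccccc1Cl` gives 30600 nM, so these two sit level, within the scatter, at the low end of the three numbers. Compound 3 `COc1ccc(/C=C2\CCC/C(=C\c3ccc([N+](=O)[O-])cc3)C2=O)cc1` stands well apart at 435000 nM, a gap from compound 2 that lies beyond the scatter.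

Compound 2 carries 2-chlorophenyl twice. Compound 4 `COc1ccc(/C=C2\CCC/C(=C\c3ccccc3Cl)C2=O)cc1` keeps one of these groups and has 4-methoxyphenyl in place of the other 2-chlorophenyl, on a double-bonded chain carbon bound to a double-bonded ring carbon: 4-methoxyphenyl in place of 2-chlorophenyl on a double-bonded chain carbon bound to a double-bonded ring carbon.

Within the data shown here, no two measured compounds differ in only one place, so the size of this step cannot be read directly from the data. Among the measured compounds shown here, the only guide is compound 3, which also carries 4-methoxyphenyl and gives 435000 nM, although its other group differs from that of compound 4. On that thin evidence, an upward move in this assay is expected, towards lower toxicity, ending partway to the number of compound 3.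

The estimated change is a 3.1-fold higher number from compound 2 to compound 4 (0.49 log units; beyond the scatter). For compound 4 the expected value is 95000 nM, with an estimated range from 35000 nM to 280000 nM.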

Compound 4, half-maximal cytotoxic concentration: 238000 nM
Estimate against measurement, compound 4: 2.5-fold (0.40 log units) below; the measured number falls inside the stated range.
By their numbers in this assay, from the lowest: compounds 2 and 1 (each within the scatter of the next); then compounds 4 and 3 (each within the scatter of the next).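

Replacing one 2-chlorophenyl with 4-methoxyphenyl, on a double-bonded chain carbon bound to a double-bonded ring carbon, brings a 7.8-fold higher number from compound 2 to compound 4 (0.89 log units; beyond the scatter) in this assay and so moves the read-out towards lower toxicity in this test. Among these compounds, this is the first direct reading of a single change in the set, and it shows that the group at this position matters for the number. Compound 4 at 238000 nM and compound 3 at 435000 nM lie within the scatter of each other even though their second groups differ, so in this pair the second group makes no clear difference once 4-methoxyphenyl is present.

No measurement shown explains the step, and it remains unclear whether the rise comes from losing 2-chlorophenyl or from gaining 4-methoxyphenyl. An unsubstituted phenyl at this position would help separate those two readings, and a ring carrying an amine or a carboxylic acid would show whether the same rise appears with a very different kind of group.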